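A Third Variation at the Benzyl Ether of the Shared Core

The source may hold more compounds than are shown below. What is called first, only, known or untested is meant among the compounds shown, and "the series" means these compounds.

Of the compounds shown here, three sharing one core have been measured in a functional assay on A-375 cells (Homo sapiens) for antiproliferative activity, read by MTT assay, with a stated time of 24 h; a lower number here means a stronger inhibitor, a higher number a weaker inhibitor. Compound 1 `COc1cc(OC)c(-c2coc3cc(OCc4ccccc4F)ccc3c2=O)cc1OC` gives 2100 nM, compound 2 `COc1cc(OC)c(-c2coc3cc(OCc4ccccc4C)ccc3c2=O)cc1OC` gives 1360 nM, and compound 3 `COc1cc(OC)c(-c2coc3cc(OCc4ccc(C#N)cc4)ccc3c2=O)cc1OC` gives 1550 nM. Compound 3 sits second highest of the three numbers, nearest to compound 2 and furthest from compound 1, with both gaps within the scatter. Compound 4 `COc1cc(OC)c(-c2coc3cc(OCc4cccc(C(F)(F)F)c4)ccc3c2=O)cc1OC` differs from compound 3 in one place: 3-(trifluoromethyl)phenyl in place of 4-cyanophenyl on a saturated chain carbon bound to an oxygen on an aromatic ring.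

Two earlier steps also change the aryl group on a saturated chain carbon bound to an oxygen on an aromatic ring, and both were small: a 1.4-fold lower number from compound 1 to compound 3 (0.13 log units; within the scatter) and a 1.1-fold higher number from compound 2 to compound 3 (0.06 log units; within the scatter). The remaining step, a 1.5-fold lower number from compound 1 to compound 2 (0.19 log units; within the scatter), was small as well. Nothing among these three compounds suggests that a further change of this kind moves this assay beyond its scatter, so the step of a 1.0-fold lower number from compound 3 to compound 4 (0.01 log units; within the scatter) is expected to stay within it. Compound 4 is therefore estimated at 1500 nM in this assay, with a range from 700 nM to 3200 nM.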

Compound 4, half-maximal inhibitory concentration: 1140 nM
For compound 4 the middle estimate is 1.3-fold (0.12 log units) above the measured one, within the range that was stated.
By their numbers in this assay, from the lowest: compounds 4, 2, 3 and 1 (each within the scatter of the next).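

Against all three earlier aryl groups, 3-(trifluoromethyl)phenyl on a saturated chain carbon bound to an oxygen on an aromatic ring leaves this assay within the scatter: a 1.4-fold lower number from compound 3 to compound 4 (0.13 log units; within the scatter), a 1.2-fold lower number from compound 2 to compound 4 (0.08 log units; within the scatter) and a 1.8-fold lower number from compound 1 to compound 4 (0.27 log units; within the scatter). Among these compounds, the step from 4-cyanophenyl adds something the earlier steps did not show: the hydrogen-bond acceptor counted in that group is absent from 3-(trifluoromethyl)phenyl, and the number still does not move beyond the scatter. No measurement given here accounts for how small these steps are.

On these data alone, all four compounds carry a substituted phenyl at this place, so it remains open whether an amine or a carboxylic acid on that ring would move the number beyond the scatter. A longer chain between the oxygen and the ring is equally untested by these compounds.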